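The source may hold more compounds than are shown below. What is called first, only, known or untested is meant among the compounds shown, and "the series" means these compounds.

For the measured compounds named here, compound 2 `ClCc1ccccc1Cn1cnc2ncnc(Cl)c21` sits at the top of the three numbers so far in a functional assay on OVCAR-3 cells (Homo sapiens) for cytotoxicity, read by sulforhodamine B assay, with a stated time of 48 h (on this read-out lower numbers stand for stronger inhibition of growth and higher numbers for weaker inhibition of growth), where compound 2 gives 4160 nM. Its nearest neighbour is compound 1 `ClCc1cccc(Cn2cnc3c(Cl)nc(Cl)nc32)c1`, which in this assay gives 3230 nM, and the furthest is compound 3 `Nc1nc(Cl)c2ncn(Cc3cccc(CCl)c3)c2n1`, which in this assay gives 2290 nM; both gaps fall within the scatter, so no order can be read among the three.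

Compound 4 `ClCc1ccccc1Cn1cnc2nc(Cl)nc(Cl)c21` differs from compound 2 by chloro in place of hydrogen on an aromatic carbon, the new group sitting between two ring nitrogen atoms of the shared core. Going by the values given here, no measured pair shows exactly this change. Among the compounds with values here, the one step that touches the same position is a 1.4-fold lower number from compound 1 to compound 3 (0.15 log units; within the scatter), which swaps amino for chloro rather than adding chloro to hydrogen and stays within the scatter. Compound 1 carries a chloro at this position while compound 2 does not, yet their values in this assay differ only within the scatter, so the addition is not expected to move the number beyond it.

Compound 4 is therefore estimated at 3500 nM in this assay, with a range of 1500 nM to 8000 nM. This expectation amounts to a 1.2-fold lower number from compound 2 to compound 4 (0.08 log units; within the scatter), a step no larger than the scatter.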

Compound 4, concentration for total growth inhibition: 27500 nM
The estimate for compound 4 lay 7.9-fold (0.90 log units) below the measured number; measured number outside the range, above it.
By their numbers in this assay, from the lowest: compounds 3, 1 and 2 (each within the scatter of the next); then compound 4.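

In this assay, chloro in place of hydrogen on this aromatic carbon, between two ring nitrogen atoms, is the first change among these compounds to move the number beyond the scatter, with a 6.6-fold higher number from compound 2 to compound 4 (0.82 log units; beyond the scatter), which means weaker inhibition of growth. The earlier change at this position, amino in place of chloro, gave a 1.4-fold lower number from compound 1 to compound 3 (0.15 log units; within the scatter), so only the new step shows that a substituent here can matter in this assay. The chloro does not set the number on its own, however: compound 4 and compound 1 both carry it at this position and differ in where the chloromethyl group sits, yet in this assay compound 1 gives 3230 nM, far lower than the printed value of compound 4.

No measurement available here explains why the number rises with this chloro. The compounds shown leave open whether a methyl or a methoxy group at this position would raise the number as chloro does, and what an amine would do there with the chloromethyl group placed as in compound 2.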